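Swapping the pyridinyl group on a weak potassium channel inhibitor

A few compounds are considered here, and "the series" means these few. Any claim that something is new, unique, unknown or untested is made for them only; others in the source may bear on it.

Measured compounds:
compound 1 `Cc1cccc(-c2noc([C@H](C)NC(=O)c3cc(C4CC4)nn3C)n2)c1` gives 167 nM
compound 2 `CCc1cc(C(=O)N[C@@H](C)c2nc(-c3cccc(C)c3)no2)n(C)n1` gives 335 nM
compound 3 `Cc1ccnc(-c2noc([C@H](C)NC(=O)c3cc(C(F)(F)F)nn3C)n2)c1` gives 4470 nM

In an assay on T-REx-293 cells for inhibition of potassium channel subfamily T member 1 (Homo sapiens), read by patch clamp (a higher number here means a weaker inhibitor, a lower number a stronger inhibitor), compound 3 stands at the highest of the three numbers, and its gaps to compound 2 and compound 1 both lie beyond the scatter, so it is the weakest inhibitor here. Compound 4 `C[C@H](NC(=O)c1cc(C(F)(F)F)nn1C)c1nc(-c2ccnc(C(F)(F)F)c2)no1` differs from compound 3 in one place: 2-(trifluoromethyl)pyridin-4-yl in place of 4-methylpyridin-2-yl on an aromatic carbon. Within the data shown here, the only measured step, a 2.0-fold higher number from compound 1 to compound 2 (0.30 log units; within the scatter), concerns a different group and lies within the scatter, so it says nothing about exchanging the 4-methylpyridin-2-yl group. Among the measured compounds shown here, compound 3 also differs from compound 1 and compound 2 in that other group, so the data give no step for the change at hand. Compound 4 is therefore expected to stay close to compound 3, a step of a 2.2-fold lower number from compound 3 to compound 4 (0.35 log units; beyond the scatter). The estimate for compound 4 is 2000 nM, with a range from 500 nM to 8000 nM.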

Compound 4, half-maximal inhibitory concentration: 40 nM
Estimate against measurement, compound 4: 50-fold (1.70 log units) above; the whole stated range lies above it.
By their numbers in this assay, from the lowest: compound 4; then compounds 1 and 2 (each within the scatter of the next); then compound 3.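

This position on the shared core can strongly affect inhibition: in this assay, the exchange of 4-methylpyridin-2-yl for 2-(trifluoromethyl)pyridin-4-yl gives a 110-fold lower number from compound 3 to compound 4 (2.05 log units; beyond the scatter). The rest of the molecule stays the same, so the whole step belongs to this exchange, whereas the earlier step concerned another group and stayed within the scatter. Nothing here explains why the step is so large.

Going by these compounds, the exchange alters both the pyridine attachment and the group on that ring, so the contribution of each remains open. A 2-methylpyridin-4-yl group at this place would help separate the two.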